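The source may report more compounds than this note shows. Statements on the series, on what has been measured and on what is new or still open speak of the compounds shown alone.

Measured compounds so far:
- compound 1, `C#CCN(C)CCCCCOc1ccc2c(c1)OCCC2=O` — 4 nM
- compound 2, `C#CCN(C)CCCCCCOc1ccc2c(c1)OCCC2=O` — 117 nM

In an assay on BTI cells for inhibition of Amine oxidase [flavin-containing] B (Homo sapiens), read by fluorescence and Amplex Red, with a stated time of 15 min (on this read-out lower numbers stand for stronger inhibition and higher numbers for weaker inhibition), compound 1 gives 4 nM and compound 2 gives 117 nM. Compound 2 stands at the highest of the two numbers; its nearest neighbour is compound 1, separated by a 29-fold higher number from compound 1 to compound 2 (1.47 log units; beyond the scatter). Compound 3, `C#CCN(C)CCCCCCCCOc1ccc2c(c1)OCCC2=O`, is not yet measured. It differs from compound 2 by 2-(methyl(propargyl)amino)ethyl in place of methyl(propargyl)amino on a saturated chain carbon, six bonds along the chain from an oxygen on an aromatic ring. Within the data shown here, the only step that bears on this change is the one from compound 1 to compound 2, where lengthening the same chain by one carbon gave a 29-fold higher number from compound 1 to compound 2 (1.47 log units; beyond the scatter), a large shift towards weaker inhibition. Compound 3 lengthens the chain by two further carbons. Among the measured compounds shown here, on that single step, a further move towards weaker inhibition in this assay is expected for compound 3, though with only one step to go on the size is uncertain; the expected step is a 5.1-fold higher number from compound 2 to compound 3 (0.71 log units; beyond the scatter). The estimate for compound 3 is 600 nM, with a range of 120 nM to 3000 nM.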

Compound 3, half-maximal inhibitory concentration: 422 nM
Beside the measured number, compound 3's estimate is 1.4-fold (0.15 log units) above it; low and high end bracket the measured number.
By their numbers in this assay, from the lowest: compound 1; then compound 2; then compound 3.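

In this assay, the move towards weaker inhibition continues when 2-(methyl(propargyl)amino)ethyl replaces methyl(propargyl)amino, with a 3.6-fold higher number from compound 2 to compound 3 (0.56 log units; beyond the scatter) on this read-out, so the numbers rise with chain length across all three compounds and none goes against this. This step is smaller than the earlier one (a 29-fold higher number from compound 1 to compound 2 (1.47 log units; beyond the scatter)) even though it adds more chain, so the rise is not even along the chain, and the full change to 3-(methyl(propargyl)amino)propyl gives a 110-fold higher number from compound 1 to compound 3 (2.02 log units; beyond the scatter) in total. Nothing measured here explains the loss of inhibition with chain length.

As far as these compounds go, a shorter chain than that of compound 1 remains open, as it could extend the trend or reverse it, and so does a longer chain than that of compound 3. Also open, from the compounds shown here alone, is an allyl group in place of the propargyl group on the amine of compound 1.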